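This account rests on a few compounds, and the source may have more. Where it says the series, first, only, none or still open, it means among the compounds named here.

Cytotoxicity notes on the series. For the measured compounds named here, in an ADME assay on WEHI13 cells (Mus musculus) for cytotoxicity, read by MTT assay (on this read-out lower numbers stand for stronger inhibition and higher numbers for weaker inhibition), compound 2 `Cc1c(CN2CCCC2)cc(-c2ccc(Cl)cc2)n1Nc1ccnc2cc(Cl)ccc12` gives 2060 nM, the only number in hand. Compound 1 `Cc1cc(CNC(C)(C)C)c(C)n1Nc1ccnc2cc(Cl)ccc12` is recorded only as "not determined" (no result reported), and compound 3 `CCN(CC)Cc1cc(C)n(Nc2ccnc3cc(Cl)ccc23)c1C` likewise only as "not determined" (no result reported), so no step between measured compounds exists and compound 2 stands alone on the numbers shown. Compound 4 `Cc1c(CN2CCCC2)cc(-c2ccccc2)n1Nc1ccnc2cc(Cl)ccc12` is the next entry to be run in this assay. It differs from compound 2 by hydrogen in place of chloro on an aromatic carbon. Going by the values given here, with no measured step to lean on, the change is expected to move the read-out little, at most a modest shift toward weaker inhibition that need not clear the scatter, so the estimated step is a 1.5-fold higher number from compound 2 to compound 4 (0.16 log units; within the scatter). Compound 4 is accordingly expected to give about 3000 nM in this assay, within 1200 nM to 8000 nM.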

Compound 4, half-maximal inhibitory concentration: 3880 nM
Estimate against measurement, compound 4: 1.3-fold (0.11 log units) below; low and high end bracket the measured number.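

In this assay, for the compounds shown here, the exchange of 4-chlorophenyl for phenyl comes to a 1.9-fold higher number from compound 2 to compound 4 (0.27 log units; within the scatter) and gives the first readable step. On this step, compound 2 and compound 4 cannot be told apart, so the chloro at this place, para to a large group, is not required for a number of this size. Nothing at hand bears on a cause for this result. Open, on these data alone, is how a larger change at the same carbon would read, such as a carboxylic acid, an amine or a longer chain in place of the chloro.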